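The compounds below may be only part of what the source reports. "The series", "measured", "known", "first", "only" and "open" are said of these compounds alone.

Compound 1 `CCCCc1nc(=O)c(S(=O)(=O)c2ccc(-c3ccc(F)nc3)cc2)c(O)n1-c1c(OC)cccc1OC`: 100%
Compound 2 `CCCCc1nc(=O)c(S(=O)(=O)c2ccc(-n3ccccc3=O)cc2)c(O)n1-c1c(OC)cccc1OC`: 87%
Compound 3 `CCCCc1[nH]c(=O)c(S(=O)(=O)c2ccc(-c3ccc(F)nc3)cc2)c(O)c1-c1c(OC)cccc1OC`: "not determined" (no result reported)

These compounds were examined in an ADME assay on microsomes from liver (Homo sapiens) for metabolic stability, using NADPH, with a stated time of 10 min; a higher number here means that more of the compound is left, a lower number that less of the compound is left. Compound 1 gives 100%. Compound 2 gives 87%. The two differ in one place only, (a group of 7 heavy atoms (5 carbon, 1 nitrogen, 1 oxygen; one six-membered aromatic ring with 1 hetero atom) in place of a group of 7 heavy atoms (5 carbon, 1 nitrogen, 1 fluorine; one six-membered aromatic ring with 1 hetero atom), on an aromatic carbon), and that exchange produced a number 13 percentage points lower from compound 1 to compound 2 (beyond the scatter). Compound 3 carries the same 6-fluoropyridin-3-yl group as compound 1 but sits on a different core; the difference between the two cores is not broken down here, and in this assay compound 3 gave "not determined" (no result reported), so there is no single number for it. Compound 4 `CCCCc1[nH]c(=O)c(S(=O)(=O)c2ccc(-n3ccccc3=O)cc2)c(O)c1-c1c(OC)cccc1OC` is still to be measured in this assay. It stands to compound 3 as compound 2 stands to compound 1: the change is a group of 7 heavy atoms (5 carbon, 1 nitrogen, 1 oxygen; one six-membered aromatic ring with 1 hetero atom) in place of a group of 7 heavy atoms (5 carbon, 1 nitrogen, 1 fluorine; one six-membered aromatic ring with 1 hetero atom), on an aromatic carbon, the same change at the same place. Since compound 3 has no value, there is no starting point on the new core, so the expectation for compound 4 rests only on a number 13 percentage points lower from compound 1 to compound 2 (beyond the scatter). It also rests on the high starting level of compound 1, which gives 100%. A step of similar, modest size downward is expected on the new core, with wide uncertainty. Compound 4 is expected to give about 80%, within 55% to 100%.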

Compound 4, percent of the compound remaining: 100%
For compound 4 the middle estimate is 20 percentage points below the measured one, within the range that was stated.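

In this assay, among the compounds shown here, compound 4 gives 100% but compound 3 has no single number, so no step from compound 3 to compound 4 can be read. The compounds shown leave open whether this exchange of groups on the core of compound 3 matches the one on the core of compound 1. No measurement at hand offers an explanation for the result.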